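From 2,4-Difluorobenzyl to Pyridin-2-ylmethyl on the Shared Core

This account rests on a few compounds, and the source may have more. Where it says the series, first, only, none or still open, it means among the compounds named here.

Compound 2 `COc1ccc2[nH]c3c(c2c1)CCNC31CCN(Cc2ccc(F)cc2F)CC1` gives 2000 nM in an assay on FRT cells for positive allosteric modulation of Cystic fibrosis transmembrane conductance regulator variant N1303K (Homo sapiens), in the presence of a further agent that is not named here (on this read-out lower numbers stand for an effect already at smaller amounts and higher numbers for an effect only at larger amounts of compound), the lowest of three numbers. Compound 3 `COc1ccc2[nH]c3c(c2c1)CCNC31CCN(Cc2c(F)c(F)c(F)c(F)c2F)CC1` gives 2100 nM, within the scatter of compound 2, while compound 1 `COc1ccc2[nH]c3c(c2c1)CCNC31CCN(Cc2ccc(F)c(Cl)c2F)CC1` gives 4500 nM. Going by the values given here, the only measured step, a 2.3-fold lower number from compound 1 to compound 2 (0.35 log units; beyond the scatter), is modest and touches just a substituent on the benzyl ring. Compound 4 `COc1ccc2[nH]c3c(c2c1)CCNC31CCN(Cc2ccccn2)CC1` differs from compound 2 by pyridin-2-yl in place of 2,4-difluorophenyl on a saturated chain carbon bound to an amine nitrogen in a ring. Among the compounds with values here, no measured step exchanges the ring itself, so little bears directly on this change. For compound 4 a modest step in either direction, a 1.5-fold higher number from compound 2 to compound 4 (0.18 log units; within the scatter), is estimated. Compound 4 is therefore expected near 3000 nM in this assay, between 1000 nM and 10000 nM.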

Compound 4, half-maximal effective concentration: 11500 nM
Compound 4: middle estimate off by 3.8-fold (0.58 log units), on the low side; measured number outside the range, above it.
By their numbers in this assay, from the lowest: compounds 2 and 3 (each within the scatter of the next); then compound 1; then compound 4.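

Replacing the whole ring on a saturated chain carbon bound to an amine nitrogen in a ring moves the number further than the substituent change on the benzyl ring did (a 5.8-fold higher number from compound 2 to compound 4 (0.76 log units; beyond the scatter)). The pyridin-2-yl compound also falls behind the chloro-bearing ring (a 2.6-fold higher number from compound 1 to compound 4 (0.41 log units; beyond the scatter)), so this position does not tolerate every six-membered aromatic ring equally. Nothing shown accounts for this shift.

The compounds leave open whether the loss follows the fluorines or the ring nitrogen. A plain phenyl ring or a fluoropyridinyl ring on the same chain carbon would separate the two.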